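This account rests on a few compounds, and the source may have more. Where it says the series, first, only, none or still open, it means among the compounds named here.

Measured compounds:
compound 1 `Brc1cccc(CSc2nnc(-c3ccncc3)n2-c2ccccc2)c1`: 7040 nM
compound 2 `Fc1ccc(CSc2nnc(-c3ccncc3)n2-c2ccccc2)c(F)c1`: 10200 nM
compound 3 `O=C(CSc1nnc(-c2ccncc2)n1-c1ccccc1)N/N=C/c1ccc([N+](=O)[O-])cc1`: 15900 nM

All three share a core and were tested in a functional assay on HepG2 cells (Homo sapiens) for inhibition, read by MTT assay, with a stated time of 48 h; on this read-out higher numbers stand for weaker inhibition and lower numbers for stronger inhibition. Compound 3 gives the highest of the three numbers; its gap to compound 2 lies within the scatter, while its gap to compound 1 lies beyond it. Among these compounds only one pair differs in a single place: from compound 1 to compound 2 the change is 2,4-difluorophenyl in place of 3-bromophenyl on a saturated chain carbon bound to a sulfur, and it gave a 1.4-fold higher number from compound 1 to compound 2 (0.16 log units; within the scatter).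

Compound 4 `O=C(CSc1nnc(-c2ccncc2)n1-c1ccccc1)N/N=C/c1ccccc1F` differs from compound 3 by 2-fluorophenyl in place of 4-nitrophenyl on a carbon with a double bond to nitrogen. Going by the values given here, no measured step touches this carbon with a double bond to nitrogen, so the only guide is the exchange of one six-membered aromatic ring for another seen from compound 1 to compound 2, a step that stayed within the scatter. On that basis the step from compound 3 to compound 4 in this assay is expected to be small, with no clear direction beyond the scatter, a 1.3-fold lower number from compound 3 to compound 4 (0.12 log units; within the scatter). Compound 4 is therefore estimated at 12000 nM in this assay, within a range from 5000 nM to 30000 nM.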

Compound 4, half-maximal inhibitory concentration: 15200 nM
Beside the measured number, compound 4's estimate is 1.3-fold (0.10 log units) below it; low and high end bracket the measured number.
By their numbers in this assay, from the lowest: compounds 1, 2, 4 and 3 (each within the scatter of the next, the first and the last beyond it).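

In this assay, going by these compounds alone, changing the group on the carbon with a double bond to nitrogen gave a 1.0-fold lower number from compound 3 to compound 4 (0.02 log units; within the scatter), and this is the first step that reads out a change at this carbon. At this place, then, the read-out does not separate the two groups, even though the group that leaves has 9 heavy atoms and 2 hydrogen-bond acceptors and the group that enters has 7 heavy atoms and 0 hydrogen-bond acceptors. Nothing available accounts for this lack of separation.

On these data alone, both groups compared here are six-membered aromatic rings of carbon only, so it remains open whether the read-out would stay in the same range with a ring bearing an amine or a carboxylic acid, or with a longer chain on this carbon. Also open, as far as these compounds go, is how plain phenyl on this carbon would compare with either group, and whether a single pair can speak for other groups at this place.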